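Cytotoxicity notes: two cores, one side-chain change

The source may report more compounds than this note shows. Statements on the series, on what has been measured and on what is new or still open speak of the compounds shown alone.

Compound 1 `O=c1cc(NCc2ccccc2)sc2c([N+](=O)[O-])cc(C(F)(F)F)cc12` and compound 3 `O=c1nc(NCc2ccccc2)oc2c([N+](=O)[O-])cc(C(F)(F)F)cc12` carry the same side chain on different cores; the difference between the two cores is not broken down here. In an ADME assay on Vero cells (Chlorocebus sabaeus) for cytotoxicity, read by MTT assay, with a stated time of 48 h (on this read-out higher numbers stand for weaker inhibition and lower numbers for stronger inhibition), compound 1 gives only a limit, > 64 ug/mL. Compound 2 `O=c1cc(NCc2ccc3c(c2)OCCO3)sc2c([N+](=O)[O-])cc(C(F)(F)F)cc12` is derived from compound 1 by 2,3-dihydro-1,4-benzodioxin-6-yl in place of phenyl on a saturated chain carbon bound to a nitrogen on an aromatic ring. In this assay compound 2 likewise gives only a limit, > 64 ug/mL. The step that the two limits leave unreadable from compound 1 to compound 2 is therefore not readable, both values resting at the limit of > 64 ug/mL in this assay, at which 2 of the 3 values shown sit. Among the measured compounds shown here, compound 3 is the one compound with a number, giving 25.4 ug/mL in this assay. Compound 4 `O=c1nc(NCc2ccc3c(c2)OCCO3)oc2c([N+](=O)[O-])cc(C(F)(F)F)cc12` is not yet measured and differs from compound 3 by 2,3-dihydro-1,4-benzodioxin-6-yl in place of phenyl on a saturated chain carbon bound to a nitrogen on an aromatic ring, the same change as between compound 1 and compound 2. No size can be taken from that earlier step, since the two limits leave it unreadable. Because compound 3 gives 25.4 ug/mL and no readable step is available, compound 4 is expected to stay close, with an estimated step of a 1.3-fold higher number from compound 3 to compound 4 (0.10 log units; within the scatter). Compound 4 is thus estimated at about 32 ug/mL, within roughly 14 ug/mL to 70 ug/mL.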

Compound 4, half-maximal inhibitory concentration: 25.3 ug/mL
For compound 4 the middle estimate is 1.3-fold (0.10 log units) above the measured one; low and high end bracket the measured number.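

In this assay, placing 2,3-dihydro-1,4-benzodioxin-6-yl on the core of compound 3 gives a 1.0-fold lower number from compound 3 to compound 4 (0.00 log units; within the scatter), so on this core the larger group, with its added ring and two hydrogen-bond acceptors, leaves the read-out within the usual scatter. Among the compounds shown here, this does not show that the change carries over from one core to the other, as only one of the two steps has a size and no two sizes can be compared. The same change on the core of compound 1 cannot be read, since compound 1 and compound 2 each give only a limit of the assay: the limit of > 64 ug/mL in this assay, at which 2 of the 4 values shown sit.

The compounds shown leave open how an amine, a carboxylic acid or a longer chain in place of phenyl would read in this assay on either core. They also leave open whether a step of this size would hold for any other ring on the saturated chain carbon.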